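The source may report more compounds than this note shows. Statements on the series, on what has been measured and on what is new or still open speak of the compounds shown alone.

Three compounds have been measured in an ADME assay on RAW264.7 cells (Mus musculus) for cytotoxicity, read by MTT assay, with a stated time of 48 h; a lower number here means a stronger inhibitor, a higher number a weaker inhibitor:

Compound 1 `CS(=O)(=O)Nc1ccc(NC(=O)c2ccc(Cl)cc2)cc1Cl` gives 79900 nM.
Compound 2 `CS(=O)(=O)Nc1ccc(NC(=O)c2cccc(C(F)(F)F)c2)cc1Cl` gives only a limit of the assay, > 250000 nM.
Compound 3 `CS(=O)(=O)Nc1ccc(NC(=O)c2ccc(Cl)cc2)cc1F` gives 22300 nM.

Compound 3 differs from compound 1 by fluoro in place of chloro on an aromatic carbon, and this change gave a 3.6-fold lower number from compound 1 to compound 3 (0.55 log units; beyond the scatter). For compound 2 the result is a limit only (the limit of > 250000 nM in this assay, at which 1 of the 3 values shown sits), so the difference between the core of compound 1 and the core of compound 2 is not broken down here.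

Compound 4 `CS(=O)(=O)Nc1ccc(NC(=O)c2cccc(C(F)(F)F)c2)cc1F` has not yet been measured. It differs from compound 2 by fluoro in place of chloro on an aromatic carbon, the same change that was seen from compound 1 to compound 3. Because the earlier change gave a 3.6-fold lower number from compound 1 to compound 3 (0.55 log units; beyond the scatter), a step of similar direction, an at least 1.6-fold lower number from compound 2 to compound 4 (0.22 log units; that floor lies within the scatter), is expected from compound 2 to compound 4, though the starting point being a limit makes the size uncertain. Compound 4 is therefore estimated at 150000 nM, expected to lie between 50000 nM and 400000 nM.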

Compound 4, half-maximal inhibitory concentration: 32300 nM
Compound 4: the middle estimate sits 4.6-fold (0.67 log units) above what was measured; measured number below the stated range.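

In this assay, putting fluoro in place of chloro on the aromatic carbon ortho to a methanesulfonamido group again lowers the number, with an at least 7.7-fold lower number from compound 2 to compound 4 (0.88 log units; beyond the scatter). The direction of the change therefore carries over between these two cores, but a shared size is not shown: the same change on two cores in this assay, a 3.6-fold lower number (0.55 log units; beyond the scatter) from compound 1 to compound 3 and an at least 7.7-fold lower number (0.88 log units; beyond the scatter) from compound 2 to compound 4; the limit leaves it open whether they differ. Compound 2 gives > 250000 nM, which is a limit of the assay and not a number.

The compounds shown leave open whether the same direction holds when the chloro or trifluoromethyl group on the other ring gives way to a nitrile or a methoxy group. They also leave open what a plain hydrogen in place of the fluoro or chloro would give.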